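A few compounds are considered here, and "the series" means these few. Any claim that something is new, unique, unknown or untested is made for them only; others in the source may bear on it.

Working notes on the series. For the measured compounds named here, compound 3 `CC(=O)N1CCCC(NC(=O)c2ccncc2Nc2cc(-c3ccc4ccn(C)c4c3)c3nccnc3c2)C1` gives 11 nM in an assay for inhibition of 6-phosphofructo-2-kinase/fructose-2,6-bisphosphatase 3 (Homo sapiens), read by ADP-Glo, with a stated time of 2 h (on this read-out higher numbers stand for weaker inhibition and lower numbers for stronger inhibition), the lowest number of the three measured so far. Compound 1 `CNS(=O)(=O)c1ccccc1Nc1cc(-c2ccc3ccn(C)c3c2)c2nccnc2c1` gives 104 nM in this assay, and compound 2 `Cn1ccc2ccc(-c3cc(Nc4ccccc4S(=O)(=O)Nc4cncnc4)cc4nccnc34)cc21` gives 1690 nM in this assay; both stand clearly above compound 3. Going by the values given here, the single step measured within the set, a 16-fold higher number from compound 1 to compound 2 (1.21 log units; beyond the scatter), sits on a sulfonamide nitrogen and is large, but it does not touch the part of the molecule altered next.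

Compound 4 `CC(=O)N1CCC(NC(=O)c2ccncc2Nc2cc(-c3ccc4ccn(C)c4c3)c3nccnc3c2)C1` differs from compound 3 by 1-acetylpyrrolidin-3-yl in place of 1-acetylpiperidin-3-yl on an amide-type nitrogen. Among the compounds with values here, no measured step bears on this change: the (1-acetylpiperidin-3-yl)carbamoyl group of compound 3 has no counterpart in compound 1 or compound 2, and the exchange of 1-acetylpiperidin-3-yl for 1-acetylpyrrolidin-3-yl is not sampled anywhere in the set. The two groups are close in size and composition, so no step beyond the scatter is expected in this assay, in either direction, while the lack of precedent widens the range. Compound 4 is therefore expected to give 15 nM, between 5 nM and 45 nM. The expected step of a 1.4-fold higher number from compound 3 to compound 4 (0.13 log units; within the scatter) lies within the scatter.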

Compound 4, half-maximal inhibitory concentration: 105 nM
The estimate for compound 4 lay 7.0-fold (0.85 log units) below the measured number, and the stated range ends below it.
By their numbers in this assay, from the lowest: compound 3; then compounds 1 and 4 (each within the scatter of the next); then compound 2.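

In this assay, the amide-type nitrogen substituent proves sensitive to ring size, with 1-acetylpyrrolidin-3-yl in place of 1-acetylpiperidin-3-yl giving a 9.5-fold higher number from compound 3 to compound 4 (0.98 log units; beyond the scatter). The two groups have the same counts of hydrogen-bond donors and acceptors and the same net charge, so this beyond-scatter step accompanies a change from a six-membered to a five-membered non-aromatic ring, a change that the earlier sulfonamide step could not address. No supporting measurement in hand bears on the origin of this step.

For the compounds shown here, with only this pair sampled at the position, the trend with ring size remains undefined, and an azepane ring or an open-chain amide substituent could test whether it extends further. Also open, on these data alone, is whether the acetyl group contributes to the low number of compound 3, which a free piperidine amine or a methanesulfonyl group in its place would address.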